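A few compounds are considered here, and "the series" means these few. Any claim that something is new, unique, unknown or untested is made for them only; others in the source may bear on it.

Compound 2 `Cc1nc(S(C)(=O)=O)ccc1Oc1ncnc(OC2CCN(C(=O)OC3COC3)CC2)c1F` gives 2500 nM in a functional assay on isolated protein for inhibition of Glucose-dependent insulinotropic receptor (Rattus norvegicus), read by HTRF and cAMP accumulation (a lower number here means that less compound is needed, a higher number that more compound is needed for the effect), the highest of the two numbers here; compound 1 `Cc1nc(S(C)(=O)=O)ccc1Oc1ncnc(OC2CCN(C(=O)OC3CCC3)CC2)c1F` gives 167 nM. Going by the values given here, the only measured step, a 15-fold higher number from compound 1 to compound 2 (1.18 log units; beyond the scatter), shows that the group on this carbonyl matters. Compound 3 `Cc1nc(S(C)(=O)=O)ccc1Oc1ncnc(OC2CCN(C(=O)C(F)(F)F)CC2)c1F` carries trifluoromethyl in place of (oxetan-3-yl)oxy on a carbonyl carbon. Among the compounds with values here, no measured step covers the trifluoromethyl, so the direction is uncertain, but the size of the step from compound 1 to compound 2 suggests that any change here may be sizeable. Compound 3 is expected to give 800 nM, between 150 nM and 4000 nM, an estimated 3.1-fold lower number from compound 2 to compound 3 (0.49 log units; beyond the scatter).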

Compound 3, half-maximal effective concentration: 880 nM
Estimate against measurement, compound 3: 1.1-fold (0.04 log units) below; the measured number falls inside the stated range.
By their numbers in this assay, from the lowest: compound 1; then compound 3; then compound 2.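

Trifluoromethyl in place of (oxetan-3-yl)oxy on a carbonyl carbon gives a 2.8-fold lower number from compound 2 to compound 3 (0.45 log units; beyond the scatter) in this assay and so shows that a group with no ring and no hydrogen-bond acceptors can give a lower number here than the oxetane. The same group against cyclobutyloxy gives a 5.3-fold higher number from compound 1 to compound 3 (0.72 log units; beyond the scatter) and leaves cyclobutyloxy with the lowest number of the three groups. Nothing available accounts for this order. Still open, going by these compounds, is whether an amine or a longer chain on this carbonyl carbon would match cyclobutyloxy, and whether the order would hold with a change elsewhere on the shared core.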